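A few compounds are considered here, and "the series" means these few. Any claim that something is new, unique, unknown or untested is made for them only; others in the source may bear on it.

Compound 1 `O=C(CI)NCCCCCC(=O)NCCCCCCNc1ncnc2c1ncn2[C@@H]1O[C@H](COP(=O)(O)OP(=O)(O)OP(=O)(O)O)[C@@H](O)[C@H]1O`: 0%
Compound 2 `Nc1ncnc2c1nc(NCCCCCCCCNC(=O)CI)n2[C@@H]1O[C@H](COP(=O)(O)OP(=O)(O)OP(=O)(O)O)[C@@H](O)[C@H]1O`: 0%
Compound 3 `O=C(CI)NCCCNc1ncnc2c1ncn2[C@@H]1O[C@H](COP(=O)(O)OP(=O)(O)OP(=O)(O)O)[C@@H](O)[C@H]1O`: 0%

Of the compounds shown here, three have so far been measured in an assay on isolated protein for inhibition of hexokinase-3 (Rattus norvegicus), with a stated time of 6 h, tested at 10 mM; on this read-out lower numbers stand for less inhibition and higher numbers for more inhibition at the one concentration tested (going by the name of the read-out). Compound 1 gives 0%, compound 2 gives 0% and compound 3 gives 0%. Compound 1 thus stands level with compounds 2 and 3 at the digits reported, nearest to compound 2 and furthest from compound 3, and in both cases the gap lies within the scatter.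

Compound 4 `O=C(CI)NCCCCCCC(=O)NCCCCCCNc1ncnc2c1ncn2[C@@H]1O[C@H](COP(=O)(O)OP(=O)(O)OP(=O)(O)O)[C@@H](O)[C@H]1O` has not yet been measured. It differs from compound 1 in one place: (((iodomethyl)carbonyl)amino)methyl in place of ((iodomethyl)carbonyl)amino on a saturated chain carbon, five bonds along the chain from a carbonyl carbon. Within the data shown here, no pair of measured compounds differing in a single place is available, so the size of this change cannot be read from a measured step.

Since all three measured compounds sit at the same level, compound 4 is expected to give 0%, with a range from 0% to 10%. The expected step of no change at the digits printed from compound 1 to compound 4 (within the scatter) is estimated to lie within the scatter, with no change in either direction.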

Compound 4, a percentage reported as inhibition, at one concentration (the size of the read-out at that concentration, not a potency): 0%
Beside the measured number, compound 4's estimate shows no gap at the digits printed; measured number inside the range.
By their numbers in this assay, from the lowest: compounds 1, 2, 3 and 4 (each within the scatter of the next).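

In this assay, among these compounds, the exchange of ((iodomethyl)carbonyl)amino for (((iodomethyl)carbonyl)amino)methyl on a saturated chain carbon, five bonds along the chain from a carbonyl carbon, gives no change at the digits printed from compound 1 to compound 4 (within the scatter) and is the first single-place step available for this position. At this position, the change therefore leaves the read-out where it was. No measurement offered here explains this result.

From the compounds shown here alone, it remains open whether a longer chain, such as 4-(((iodomethyl)carbonyl)amino)butyl, would shift the read-out. The same question applies to a carboxylic acid or an amine in place of the iodomethyl carbonyl amino group.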